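This account rests on a few compounds, and the source may have more. Where it says the series, first, only, none or still open, it means among the compounds named here.

Compound 1 `COc1cc(-c2cc(/C=C/C(=O)c3ccc(N)cc3)[nH]n2)cc(OC)c1OC` and compound 2 `COc1ccc(-c2cc(/C=C/C(=O)c3cc(OC)c(OC)c(OC)c3)[nH]n2)cc1OC` share a core, and both were examined in a functional assay on SK-MEL-2 cells (Homo sapiens) for cytotoxicity, read by sulforhodamine B assay, with a stated time of 48 h, tested at 0.1 uM; on this read-out higher numbers stand for a weaker effect at the one concentration tested and lower numbers for a stronger effect. Compound 1 gives 111%, the highest of the two numbers shown. Compound 2 gives 95%, a number lower than that of compound 1 by a margin beyond the scatter; even so, both numbers sit at a level where only a modest effect is seen at this single concentration. Compound 3 `COc1ccc(C(=O)/C=C/c2cc(-c3cc(OC)c(OC)c(OC)c3)n[nH]2)cc1OC` has not yet been measured. Compared with compound 1 it carries 3,4-dimethoxyphenyl in place of 4-aminophenyl on a carbonyl carbon. No measured pair differs in only this one place, so the size of the step cannot be read directly from the numbers shown. Because compound 2, which also has no amino group, gives 95%, the change is taken to leave the weak effect largely in place. For compound 3 a small shift towards a stronger effect, probably not beyond the scatter, is expected, a number 11 percentage points lower from compound 1 to compound 3 (beyond the scatter). Compound 3 is therefore estimated to give about 100% in this assay, with a range from 82% to 118%.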

Compound 3, a percentage reported as activity, at one concentration (the size of the read-out at that concentration, not a potency): 91%
Compound 3: middle estimate off by 9 percentage points, on the high side, within the range that was stated.
By their numbers in this assay, from the lowest: compounds 3 and 2 (each within the scatter of the next); then compound 1.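

In this assay, within the data shown here, placing 3,4-dimethoxyphenyl instead of 4-aminophenyl on the carbonyl carbon gives the first step that can be read directly at this position: a number 20 percentage points lower from compound 1 to compound 3 (beyond the scatter). The group at this position therefore does change the read-out, although the step is modest and compound 3, at 91%, still shows only a weak effect at the single concentration tested. No available evidence bears on why this exchange shifts the number.

The compounds shown leave open whether the step follows from the loss of the amine, the arrival of the two methoxy groups, or both together, since this single exchange alters all of these at once with the rest of the structure held fixed. As far as these compounds go, it also remains open how a plain phenyl, a 4-methoxyphenyl or a 4-hydroxyphenyl would stand on the same carbonyl carbon, and whether the step between these two groups would hold at any other concentration.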